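The source may report more compounds than this note shows. Statements on the series, on what has been measured and on what is new or still open speak of the compounds shown alone.

Measured so far in an ADME assay on MT4 cells (Homo sapiens) for cytotoxicity, read by MTT assay (a higher number here means that more compound is tolerated, a lower number that less compound is tolerated), for the series:
- compound 1 `O=C(CSc1nncnc1-c1ccccc1Cl)c1ccc(Br)cc1Br` gives 28000 nM
- compound 2 `Cc1ccc2sc(NC(=O)CSc3nncnc3-c3ccccc3Cl)nc2c1` gives 137000 nM

Compound 1 at 28000 nM holds the lower of the two numbers, and the gap up to compound 2 lies beyond the usual scatter. Compound 3 `O=C(CSc1nncnc1-c1ccccc1Cl)Nc1ccccn1` differs from compound 1 by (pyridin-2-yl)amino in place of 2,4-dibromophenyl on a carbonyl carbon and, in words, carries (pyridin-2-yl)amino in place of 2,4-dibromophenyl on a carbonyl carbon. Within the data shown here, no measured pair isolates this change, so the basis for any expectation is thin. Among the measured compounds shown here, compound 2 at 137000 nM also carries an amino link on the carbonyl carbon, and this is the only guide towards a higher number. The step expected is a 3.6-fold higher number from compound 1 to compound 3 (0.55 log units; beyond the scatter) in the upward direction, beyond the scatter. Compound 3 is estimated at 100000 nM with 30000 nM and 300000 nM as the expected ends of the range.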

Compound 3, half-maximal cytotoxic concentration: 172000 nM
Beside the measured number, compound 3's estimate is 1.7-fold (0.24 log units) below it; low and high end bracket the measured number.
By their numbers in this assay, from the lowest: compound 1; then compounds 2 and 3 (each within the scatter of the next).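

In this assay the carbonyl carbon now has its first comparison that differs in one place: (pyridin-2-yl)amino in place of 2,4-dibromophenyl gives a 6.1-fold higher number from compound 1 to compound 3 (0.79 log units; beyond the scatter) and shows that this position alone can move the tolerated concentration beyond the scatter. Compound 2 and compound 3, which both carry an amino link on the carbonyl carbon, lie within the scatter of each other, while compound 1 stands lowest of the three. No measured data that could explain this step are available.

The step combines the arrival of the amino link and pyridine ring with the loss of both bromines, and the compounds shown do not separate these parts. Phenylamino or plain phenyl on the carbonyl carbon would help to tell them apart.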